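Removing a boron-bearing group from compound 1

The compounds below may be only part of what the source reports. "The series", "measured", "known", "first", "only" and "open" are said of these compounds alone.

For the measured compounds named here, in a functional assay on PANC-1 cells (Homo sapiens) for cytotoxicity, read by MTT assay, with a stated time of 48 h, in the presence of a further agent that is not named here (on this read-out higher numbers stand for weaker inhibition and lower numbers for stronger inhibition), compound 1 (`O=C(c1ccc2cccc(OCc3ccc(B(O)O)cc3)c2n1)N1CCC(Oc2no[n+]([O-])c2S(=O)(=O)c2ccccc2)CC1`) gives 20500 nM and compound 2 (`CC1(C)OB(c2ccc(COc3cccc4ccc(C(=O)N5CCC(Oc6no[n+]([O-])c6S(=O)(=O)c6ccccc6)CC5)nc34)cc2)OC1(C)C`) gives 38300 nM as its value, so compound 1 stands within the scatter of the only other measured compound. The step of a 1.9-fold higher number from compound 1 to compound 2 (0.27 log units; within the scatter) alters only the boron-bearing end of the group and stays within the scatter. Compound 3 (`O=C(c1ccc2cccc(O)c2n1)N1CCC(Oc2no[n+]([O-])c2S(=O)(=O)c2ccccc2)CC1`), still unmeasured, differs by a hydrogen atom in place of a group of 10 heavy atoms (7 carbon, 1 boron, 2 oxygen; one six-membered aromatic ring of carbon only), on an oxygen on an aromatic ring and thus loses that whole group. Going by the values given here, the one measured step is the only evidence that bears on this change, and no measured compound lacks the group, so it sets no firm size for the removal. A moderate move toward a lower number is tentatively expected in this assay and the expected change is a 2.6-fold lower number from compound 1 to compound 3 (0.41 log units; beyond the scatter) with wide uncertainty. Compound 3 is estimated at 8000 nM with an expected range from 2000 nM to 30000 nM here.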

Compound 3, half-maximal inhibitory concentration: 14800 nM
The estimate for compound 3 lay 1.9-fold (0.27 log units) below the measured number; measured number inside the range.
By their numbers in this assay, from the lowest: compounds 3, 1 and 2 (each within the scatter of the next, the first and the last beyond it).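

In this assay, replacing the whole group on the oxygen on the aromatic ring with a hydrogen atom gives a 1.4-fold lower number from compound 1 to compound 3 (0.14 log units; within the scatter). The earlier step altered only the boron-bearing end, whereas this one removes that end together with the six-membered aromatic ring that carries it, and compound 3 still cannot be separated from compound 1 on this read-out. Nothing measured here accounts for this result.

The compounds shown leave open whether a plain benzyl group, with no boron, would read any differently from compound 1 in this assay. They also leave open whether a smaller or differently built group on this oxygen, such as a methyl group, a carboxylic acid or a chain ending in an amine, would move the number beyond the scatter.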